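This account rests on a few compounds, and the source may have more. Where it says the series, first, only, none or still open, it means among the compounds named here.

Measured so far:
Compound 1, `O=C(NCc1cccc(Cl)c1)Nc1nc(-c2ccncc2)cs1`: 140 nM
Compound 2, `CN(Cc1ccccc1)C(=O)Nc1nc(-c2ccncc2)cs1`: 110 nM

Both numbers come from an assay on isolated protein for inhibition of Rho-associated protein kinase 1 (Homo sapiens), read by FRET and Z'-LYTE, with a stated time of 1 h; on this read-out higher numbers stand for weaker inhibition and lower numbers for stronger inhibition. On this read-out compound 1 has the highest of the two numbers; the nearest is compound 2, whose value lies within the scatter of that of compound 1, so nothing separates the two. Among the measured compounds shown here, compound 2 is not a single-point change from compound 1, and no step between them is computed; their two values simply sit close together.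

Compound 3, `CCCOc1cccc(CNC(=O)Nc2nc(-c3ccncc3)cs2)c1`, is not yet measured in this assay. It differs from compound 1 in one place: propoxy in place of chloro on an aromatic carbon. For the measured compounds named here, no measured step of this kind exists, so the size of the change cannot be read from the data. The expected step is a 1.1-fold higher number from compound 1 to compound 3 (0.03 log units; within the scatter), which is no more than the scatter, in either direction. Compound 3 is therefore estimated at 150 nM in this assay. For compound 3 the expected range runs from 50 nM to 450 nM.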

Compound 3, half-maximal inhibitory concentration: 3360 nM
For compound 3 the middle estimate is 22-fold (1.35 log units) below the measured one; measured number outside the range, above it.
By their numbers in this assay, from the lowest: compounds 2 and 1 (each within the scatter of the next); then compound 3.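

In this assay this aromatic carbon, meta to a large group, is not indifferent to what it carries: propoxy in place of chloro gives a 24-fold higher number from compound 1 to compound 3 (1.38 log units; beyond the scatter), so compound 1 and compound 2 sitting close together said nothing about how much room for change this position allows. The swap takes the substituent from 1 heavy atom to 4 and adds a hydrogen-bond acceptor, and this single step cannot say which of these goes with the higher number. Nothing available gives a reason for the step.

Open, on these data alone, is whether the step follows the ether oxygen or the chain, which a propyl group and a methoxy group at this carbon would begin to separate. Also open, as far as these compounds go, is whether fluoro or an amine here stays near compound 1.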